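The source may hold more compounds than are shown below. What is called first, only, known or untested is meant among the compounds shown, and "the series" means these compounds.

Compound 1 `C=C1C(=O)[C@]23C[C@@]1(I)CC[C@H]2[C@@]12C=CC(=O)[C@](C)(C(=O)O1)[C@H]2[C@@H]3C(=O)OC` has a core of fused and bridged rings carrying a methoxycarbonyl group; in a functional assay on HepG2 cells (Homo sapiens) for cytotoxicity, read by MTT assay (on this read-out lower numbers stand for stronger inhibition and higher numbers for weaker inhibition), compound 1 gives 87000 nM. Compound 2 `C=C1C(=O)[C@]23C[C@@]1(I)CC[C@H]2[C@@]12C=CC(=O)[C@](C)(C(=O)O1)[C@H]2[C@@H]3C(=O)OCc1ccccc1` differs from it only by phenyl in place of hydrogen on a saturated chain carbon bound to an oxygen next to a carbonyl group, and in this assay compound 2 gives 69500 nM. That change made a 1.3-fold lower number from compound 1 to compound 2 (0.10 log units; within the scatter).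

Compound 3 `C=C1C(=O)[C@]23C[C@@]1(OCC)CC[C@H]2[C@@]12C=CC(=O)[C@](C)(C(=O)O1)[C@H]2[C@@H]3C(=O)OC` carries a different core: its difference from compound 1 is ethoxy in place of iodo on a saturated ring carbon. In this assay compound 3 gives 120000 nM, and the change from compound 1 to compound 3 made a 1.4-fold higher number from compound 1 to compound 3 (0.14 log units; within the scatter).

Compound 4 `C=C1C(=O)[C@]23C[C@@]1(OCC)CC[C@H]2[C@@]12C=CC(=O)[C@](C)(C(=O)O1)[C@H]2[C@@H]3C(=O)OCc1ccccc1` stands to compound 3 as compound 2 stands to compound 1: the difference is phenyl in place of hydrogen on a saturated chain carbon bound to an oxygen next to a carbonyl group, the same change at the same place, made on the core of compound 3 instead of the core of compound 1. Since the same change shifted nothing beyond the scatter from compound 1 to compound 2, the expectation for compound 4 is a step of about a 1.3-fold lower number from compound 3 to compound 4 (0.10 log units; within the scatter) from compound 3, again within the scatter. In this assay compound 4 is therefore expected to give about 95000 nM, somewhere between 50000 nM and 180000 nM.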

Compound 4, half-maximal inhibitory concentration: 29600 nM
Estimate against measurement, compound 4: 3.2-fold (0.51 log units) above; measured number outside the range, below it.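

Replacing methoxycarbonyl with benzyloxycarbonyl in this assay gives a 4.1-fold lower number from compound 3 to compound 4 (0.61 log units; beyond the scatter), so this change does not carry over at one fixed size from one core to the other: the same change on two cores in this assay, a 1.3-fold lower number (0.10 log units; within the scatter) from compound 1 to compound 2 and a 4.1-fold lower number (0.61 log units; beyond the scatter) from compound 3 to compound 4, 3.2-fold (0.51 log units) apart, beyond the scatter of two such steps.

The same mismatch appears when the pairs are read the other way, with ethoxy in place of iodo on a saturated ring carbon giving a 2.3-fold lower number from compound 2 to compound 4 (0.37 log units; beyond the scatter), and the two changes therefore do not add up independently in these four compounds: the same change on two cores in this assay, a 1.4-fold higher number (0.14 log units; within the scatter) from compound 1 to compound 3 and a 2.3-fold lower number (0.37 log units; beyond the scatter) from compound 2 to compound 4, 3.2-fold (0.51 log units) apart, beyond the scatter of two such steps.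

This rests on a single pair of steps for each change, so it shows that the size of a step depended on the core here, but it does not show why, nor how the change would behave on any other core.

The compounds shown leave open whether a longer chain or a carboxylic acid in place of the benzyloxycarbonyl group would give a step as large as the one on the ethoxy core. They also leave open whether an amine in place of ethoxy on that ring carbon would do the same.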